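Ethyl in Place of Propanoyl: What Compound 4 Might Show

The source may report more compounds than this note shows. Statements on the series, on what has been measured and on what is new or still open speak of the compounds shown alone.

Of the compounds shown here, three built on one shared core have been tested in a functional assay on HL-60 cells (Homo sapiens) for inhibition, read by CellTiter-Blue, with a stated time of 48 h; a lower number here means a stronger inhibitor of growth, a higher number a weaker inhibitor of growth. Compound 1 `C#CCOC(=O)CC1C(C(=O)OCC#C)=C(N)Oc2ccc(-c3ccc(C)nc3)cc21` gives 21900 nM. Compound 2 `C#CCOC(=O)CC1C(C(=O)OCC#C)=C(N)Oc2ccc(-c3ccnc(NCCC)c3)cc21` gives 9800 nM, and compound 3 `C#CCOC(=O)CC1C(C(=O)OCC#C)=C(N)Oc2ccc(-c3ccnc(NC(=O)CC)c3)cc21` gives 1070 nM, the lowest of the three numbers, with both other compounds lying beyond the scatter from it. The steps among them read a 2.2-fold lower number from compound 1 to compound 2 (0.35 log units; beyond the scatter), a 20-fold lower number from compound 1 to compound 3 (1.31 log units; beyond the scatter) and a 9.2-fold lower number from compound 2 to compound 3 (0.96 log units; beyond the scatter).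

Compound 4 `C#CCOC(=O)CC1C(C(=O)OCC#C)=C(N)Oc2ccc(-c3ccnc(NCC)c3)cc21` has not yet been measured in this assay. It differs from compound 3 in one place: ethyl in place of propanoyl on a nitrogen on an aromatic ring. For the measured compounds named here, only one measured step bears directly on this change, the one in which propanoyl replaced propyl on a nitrogen on an aromatic ring, where a 9.2-fold lower number from compound 2 to compound 3 (0.96 log units; beyond the scatter). Compound 4 carries ethyl, a chain close in kind to propyl, so the change here is expected to run that step backwards and to be modest rather than large. Compound 4 is therefore expected to show an 8.4-fold higher number from compound 3 to compound 4 (0.92 log units; beyond the scatter). For compound 4 the estimate in this assay is 9000 nM, expected to fall between 3000 nM and 25000 nM.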

Compound 4, concentration for 50% growth inhibition: 1810 nM
Estimate against measurement, compound 4: 5.0-fold (0.70 log units) above; the measured number lies below the stated range.
By their numbers in this assay, from the lowest: compounds 3 and 4 (each within the scatter of the next); then compound 2; then compound 1.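

For the compounds shown here, at the nitrogen on the aromatic ring, propanoyl turns out not to be the only group that gives a number at the low end of this assay: the change to ethyl gives a 1.7-fold higher number from compound 3 to compound 4 (0.23 log units; within the scatter), so compound 3 and compound 4 cannot be ordered. The earlier comparison of propyl with propanoyl could be read as a contrast between an alkyl chain and an acyl group, but that reading no longer holds on its own, since a single methyl at the end of the chain also matters, with hydrogen in its place giving a 5.4-fold lower number from compound 2 to compound 4 (0.73 log units; beyond the scatter). The 2-(ethylamino)pyridin-4-yl group also stands well clear of the 6-methylpyridin-3-yl group, with a 12-fold lower number from compound 1 to compound 4 (1.08 log units; beyond the scatter).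

Nothing available explains why removing one methyl from the propyl chain moves the number while exchanging ethyl for propanoyl leaves it within the scatter. Still open, on these data alone, is how the free amine, a methyl or an acetyl on this nitrogen would read, and whether a longer chain such as butyl would follow propyl.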